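Aryl Sulfonamide Exchange and Cell Toxicity

The source may hold more compounds than are shown below. What is called first, only, known or untested is meant among the compounds shown, and "the series" means these compounds.

Compound 1 `Cc1cccc(S(=O)(=O)Nc2ccc3oc(-c4ccccc4)nc3c2)c1`: 69000 nM
Compound 2 `O=S(=O)(Nc1ccc2oc(-c3ccccc3)nc2c1)c1cccc(O)c1`: > 100000 nM

In an ADME assay on HEK293 cells (Homo sapiens) for cytotoxicity, read by resazurin assay, with a stated time of 48 h (on this read-out lower numbers stand for higher toxicity in this test and higher numbers for lower toxicity in this test), compound 1 gives 69000 nM. Compound 2 reaches the limit of this assay, > 100000 nM, so only a limit and no number is known for it, which means (the limit of > 100000 nM in this assay, at which 1 of the 2 values shown sits). The change from compound 1 to compound 2 is an at least 1.4-fold higher number from compound 1 to compound 2 (0.16 log units; that floor lies within the scatter). Compound 3 `CCc1ccc(S(=O)(=O)Nc2ccc3oc(-c4ccccc4)nc3c2)cc1` is not yet measured. It differs from compound 2 by 4-ethylphenyl in place of 3-hydroxyphenyl on a sulfonyl sulfur. Among the measured compounds shown here, the only measured step that bears on this, hydroxy in place of methyl on an aromatic carbon, was an at least 1.4-fold higher number from compound 1 to compound 2 (0.16 log units; that floor lies within the scatter), too small to separate from scatter; going the other way, 4-ethylphenyl returns to an alkyl-substituted ring like that of compound 1. Compound 3 is therefore expected to lie near compound 1, with a step of an at least 1.5-fold lower number from compound 2 to compound 3 (0.18 log units; that floor lies within the scatter) that may not be distinguishable from scatter. Compound 3 is estimated at 65000 nM, between 20000 nM and 150000 nM.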

Compound 3, half-maximal cytotoxic concentration: 81000 nM
Beside the measured number, compound 3's estimate is 1.2-fold (0.10 log units) below it, and the stated range covers the measured number.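

With 4-ethylphenyl in place of 3-methylphenyl on a sulfonyl sulfur, this assay shows a 1.2-fold higher number from compound 1 to compound 3 (0.07 log units; within the scatter), so the two alkyl-substituted rings cannot be told apart on this read-out. Against the ring with the hydroxy group, the result is an at least 1.2-fold lower number from compound 2 to compound 3 (0.09 log units; that floor lies within the scatter), which is only a floor, so this exchange is not shown to matter at this position either. The true size of that step remains unknown because compound 2 stands at a limit of the assay: the limit of > 100000 nM in this assay, at which 1 of the 3 values shown sits.

From the compounds shown here alone, it remains open whether an aryl ring carrying an amine or a carboxylic acid on this sulfonyl sulfur would give a step beyond the scatter. A longer chain, such as butyl, on the ring also remains untested among the compounds shown here.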